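From Phenoxy to Dimethylaminomethyl on the Benzoyl Ring

The source may report more compounds than this note shows. Statements on the series, on what has been measured and on what is new or still open speak of the compounds shown alone.

Compound 1 `Cc1c(C(=O)c2ccccc2-c2ccccc2)oc2cc(-c3ccccc3)cc(O)c12` gives 0.1 ug/mL in a functional assay on WI-38 VA13 cells (Homo sapiens) for cytotoxicity; a lower number here means that less compound is needed, a higher number that more compound is needed for the effect. Compound 3 `Cc1c(C(=O)c2cccc(OC(C)C)c2)oc2cc(-c3ccccc3)cc(O)c12` gives 0.35 ug/mL in this assay. Compound 2 `Cc1c(C(=O)c2ccc(Oc3ccccc3)cc2)oc2cc(-c3ccccc3)cc(O)c12` stands apart from both. In this assay compound 2 returns only a limit, > 4 ug/mL, so no number is known for it. Among the three values shown, this is where compound 2 sits, as the limit of > 4 ug/mL in this assay, at which 1 of the 3 values shown sits, records.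

Among the measured compounds shown here, no pair of measured compounds differs in a single place, so the step from compound 2 to compound 4 `Cc1c(C(=O)c2ccc(CN(C)C)cc2)oc2cc(-c3ccccc3)cc(O)c12` has no measured neighbour to lean on. The change is (dimethylamino)methyl in place of phenoxy on an aromatic carbon. Because compound 2 sits at a limit, any reported number for compound 4 would count as a step toward less compound being needed. The estimate for compound 4 in this assay is 1 ug/mL, expected to lie between 0.2 ug/mL and 4 ug/mL. This corresponds to an expected step of an at least 4.0-fold lower number from compound 2 to compound 4 (0.60 log units; beyond the scatter) away from the limit, beyond the usual scatter. It remains possible that compound 4 is expected to stay at a limit instead.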

Compound 4, half-maximal effective concentration: > 4 ug/mL
Compound 4: no number, only a limit; the forecaster's own chance of this, stated with the estimate: 25%; at least 4.0-fold (0.60 log units) between middle value and limit.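

Compound 2 and compound 4 each return only a limit in this assay, and the step between them cannot be read. The compounds shown leave open whether (dimethylamino)methyl in place of phenoxy changes the read-out at all, and by how much.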